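Compound 4: Two Hydroxyls Where One Methoxy Stood

A few compounds are considered here, and "the series" means these few. Any claim that something is new, unique, unknown or untested is made for them only; others in the source may bear on it.

Of the compounds shown here, three have been measured in a functional assay on HT-1080 cells (Homo sapiens) for cytotoxicity, read by MTT assay, with a stated time of 72 h; a lower number here means a stronger inhibitor, a higher number a weaker inhibitor. Compound 1 `COc1cccc(/C=C2\CCC/C(=C\c3cccc(O)c3)C2=O)c1OC` gives 8500 nM, compound 2 `COc1ccccc1/C=C1\CCC/C(=C\c2ccc(OC)c(OC)c2)C1=O` gives 8100 nM, and compound 3 `COc1ccc(/C=C2\CCC/C(=C\c3ccc(OC)c(OC)c3)C2=O)c(OC)c1` gives 17100 nM. Compound 2 has the lowest number of the three, but its gap to compound 1 lies within the scatter; only compound 3 sits beyond it, with a 2.1-fold higher number from compound 2 to compound 3 (0.32 log units; beyond the scatter).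

Compound 4 `COc1ccc(/C=C2\CCC/C(=C\c3ccc(O)c(O)c3)C2=O)cc1OC` has not yet been measured. It differs from compound 2 by 3,4-dihydroxyphenyl in place of 2-methoxyphenyl on a double-bonded chain carbon bound to a double-bonded ring carbon. Among the compounds with values here, no measured step matches this change: the single step, from compound 2 to compound 3, adds a methoxy on the other ring and is only a modest one. Compound 1, which carries a hydroxy on one ring, sits within the scatter of compound 2, so a hydroxylated ring has not so far moved the number far.

Compound 4 is therefore expected to stay close to compound 2, with an estimated 1.2-fold lower number from compound 2 to compound 4 (0.06 log units; within the scatter). The estimate in this assay for compound 4 is 7000 nM, within 3000 nM to 17000 nM.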

Compound 4, half-maximal inhibitory concentration: 4200 nM
Compound 4: middle estimate off by 1.7-fold (0.22 log units), on the high side, within the range that was stated.
By their numbers in this assay, from the lowest: compounds 4, 2, 1 and 3 (each within the scatter of the next, the first and the last beyond it).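

In this assay, within the data shown here, replacing 2-methoxyphenyl with 3,4-dihydroxyphenyl on a double-bonded chain carbon bound to a double-bonded ring carbon gives a 1.9-fold lower number from compound 2 to compound 4 (0.29 log units; within the scatter), the first measured change at this position. It shows that this place accepts a whole-group exchange, from a group without hydrogen-bond donors to one that carries them, while the number stays within the scatter of compound 2. Nothing available explains this result.

The compounds shown leave open whether the two hydroxy groups count together or singly, and whether the loss of the methoxy matters apart from them. They also leave open whether a ring bearing an amine or a carboxylic acid at this position would stay as close to compound 2.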